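Fluoro to methyl swap on the pendant aryl ring

The source may hold more compounds than are shown below. What is called first, only, known or untested is meant among the compounds shown, and "the series" means these compounds.

Measured compounds:
compound 1 `Cc1ccc(-c2nc3cccnc3o2)cc1`: 0%
compound 2 `Fc1ccc(-c2nc3cccnc3o2)cc1`: 27%
compound 3 `Fc1cccc(-c2nc3cccnc3o2)c1`: 35%

Three compounds share one core and differ only in the substituent on the pendant aromatic ring. In a functional assay on the whole organism for inhibition, with Rattus norvegicus as the target, at a dose of 30 mg/kg (a higher number here means more inhibition at the dose given (going by the name of the read-out), a lower number less inhibition), compound 1 gives 0%, compound 2 gives 27% and compound 3 gives 35%. Compound 2 and compound 3 have the same atoms joined differently; the difference between the two cores is not broken down here, and their two numbers lie within the scatter of each other.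

For the measured compounds named here, the one counted step is methyl in place of fluoro on an aromatic carbon, which gave a number 27 percentage points lower from compound 2 to compound 1 (beyond the scatter). The unmeasured compound 4 `Cc1cccc(-c2nc3cccnc3o2)c1` carries the same kind of change relative to compound 3, (methyl in place of fluoro on an aromatic carbon), the only difference around the place being that the group sits meta rather than para to a group of 9 heavy atoms.

Going by the values given here, the step from compound 3 to compound 4 in this assay is expected to be a number 27 percentage points lower from compound 3 to compound 4 (beyond the scatter), resting on the single measured precedent, the drop seen in compound 1 0% against compound 2 27%. Compound 4 is therefore estimated at 8%, with the spread allowing for a smaller drop where the substituent sits differently.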

Compound 4, a percentage reported as inhibition, in the whole organism at one dose (the size of the read-out at that dose, not a potency): 14%
Beside the measured number, compound 4's estimate is 6 percentage points below it; low and high end bracket the measured number.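

In this assay, methyl in place of fluoro on an aromatic carbon again lowers inhibition, giving a number 21 percentage points lower from compound 3 to compound 4 (beyond the scatter). Set beside the earlier step, the change carries over from one core to the other at a similar size: the same change on two cores in this assay, a number 27 percentage points lower (beyond the scatter) from compound 2 to compound 1 and a number 21 percentage points lower (beyond the scatter) from compound 3 to compound 4, 6 percentage points apart, within the scatter of two such steps. For the compounds shown here, this rests on only two matched pairs at a single dose in one assay, so it does not show that the drop would hold on any other core, and it does not explain why the drop occurs.

The compounds shown leave open how other groups on the pendant aromatic ring, such as chloro, methoxy, a nitrile, an amine or a carboxylic acid, would compare with the fluoro of compound 3 at 35%. Also open, from the compounds shown here alone, is whether the same step between fluoro and methyl appears at other doses.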